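Methyl to Formyl on the Amine Nitrogen

This account rests on a few compounds, and the source may have more. Where it says the series, first, only, none or still open, it means among the compounds named here.

Measured so far:
compound 1, `CN(c1ncnc2c1ncn2CC1CC1)C1CC1`, 35 mg/kg in a functional assay on the whole organism for antagonist activity, with Rattus norvegicus as the target; on this read-out lower numbers stand for an effect already at smaller amounts and higher numbers for an effect only at larger amounts of compound
compound 2, `CN(c1ncnc2c1ncn2C1CC1)C1CC1`, 12.5 mg/kg

Among the compounds with values here, compound 2 holds the lower of the two numbers, and the single measured step leading to it is a 2.8-fold lower number from compound 1 to compound 2 (0.45 log units; beyond the scatter). Compound 3 is `O=CN(c1ncnc2c1ncn2C1CC1)C1CC1`; its change from compound 2 reads (formyl in place of methyl on a nitrogen on an aromatic ring). Within the data shown here, this alteration sits on a different nitrogen than the one changed in the measured step, so no measured step bears on it and its size cannot be anchored. Compound 3 is therefore expected, with wide uncertainty, near 30 mg/kg, between 10 mg/kg and 100 mg/kg. The expected shift is a 2.4-fold higher number from compound 2 to compound 3 (0.38 log units; beyond the scatter).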

Compound 3, dose for half-maximal effect: 7.4 mg/kg
The estimate for compound 3 lay 4.1-fold (0.61 log units) above the measured number; measured number below the stated range.
By their numbers in this assay, from the lowest: compounds 3 and 2 (each within the scatter of the next); then compound 1.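

In this assay the swap of methyl for formyl on a nitrogen on an aromatic ring gives a 1.7-fold lower number from compound 2 to compound 3 (0.23 log units; within the scatter) and so stays within the scatter. This nitrogen therefore accepts a larger group, with a double bond and a hydrogen-bond acceptor that methyl lacks, without a change that can be read in this whole-organism test. Nothing available explains this result.

As far as these compounds go, it remains open whether an acetyl group, a longer acyl chain or a plain hydrogen on this nitrogen would give a similar number. Also open, from the compounds shown here alone, is whether the formyl result would carry over with cyclopropylmethyl on the other nitrogen.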